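Alkynyl sulfonamide series: substitution on the fused core

The source may report more compounds than this note shows. Statements on the series, on what has been measured and on what is new or still open speak of the compounds shown alone.

Three compounds of the series have numbers in a functional assay on COLO 205 cells (Homo sapiens) for antiproliferative activity, read by MTT assay, with a stated time of 68 h; on this read-out higher numbers stand for weaker inhibition and lower numbers for stronger inhibition. Compound 1 `O=S(=O)(Nc1ccc(F)c(C#Cc2cnc3[nH]ncc3c2)c1F)c1cccc(F)c1` gives 758 nM in this assay. Among the compounds with values here, compound 2 `O=S(=O)(Nc1ccc(F)c(C#Cc2cnc3[nH]ncc3c2)c1F)c1ccccn1`, which carries a pyridin-2-yl on the sulfonyl sulfur, gives 2670 nM in this assay; the step of a 3.5-fold higher number from compound 1 to compound 2 (0.55 log units; beyond the scatter) is the only single-site step among the measured compounds. Compound 3 `CCOc1n[nH]c2ncc(C#Cc3c(F)ccc(NS(=O)(=O)c4cccnc4)c3F)cc12`, with an ethoxy on the fused core and a pyridin-3-yl on the sulfonyl sulfur, gives 1980 nM in this assay. Compound 3 stands second highest of the three numbers: its nearest neighbour is compound 2, within the scatter, and its furthest is compound 1, beyond the scatter.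

Compound 4 `O=S(=O)(Nc1ccc(F)c(C#Cc2cnc3[nH]nc(-c4ccc(F)cc4)c3c2)c1F)c1cccnc1` differs from compound 3 in one place: 4-fluorophenyl in place of ethoxy on an aromatic carbon. Within the data shown here, no measured step touches the fused core; the single measured step, from compound 1 to compound 2, concerns the group on the sulfonyl sulfur and so does not bear on this change. There is therefore no basis for expecting a step in this assay in either direction beyond the scatter, and the uncertainty is wide. The expected step of a 1.2-fold lower number from compound 3 to compound 4 (0.09 log units; within the scatter) is set near zero. For compound 4 the estimate in this assay is 1600 nM, with a range from 400 nM to 6500 nM.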

Compound 4, half-maximal inhibitory concentration: 166 nM
Compound 4: middle estimate off by 9.6-fold (0.98 log units), on the high side; the measured number lies below the stated range.
By their numbers in this assay, from the lowest: compound 4; then compound 1; then compounds 3 and 2 (each within the scatter of the next).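

In this assay, within the data shown here, the replacement of ethoxy by 4-fluorophenyl on an aromatic carbon of the five-membered aromatic ring with 2 nitrogen gives a 12-fold lower number from compound 3 to compound 4 (1.08 log units; beyond the scatter) and is the first measured sign that this position can move the number well beyond the scatter; the only earlier step, a 3.5-fold higher number from compound 1 to compound 2 (0.55 log units; beyond the scatter), concerned the group on the sulfonyl sulfur. The change is not a single-feature one: 7 heavy atoms and a six-membered aromatic ring enter, while 3 heavy atoms and 1 hydrogen-bond acceptor leave, and this one pair cannot separate these differences. No available evidence accounts for the size of the step.

Going by these compounds, it remains open whether the step depends on the aromatic ring itself, on its fluorine, or on the loss of ethoxy, and a plain phenyl, a methyl or a morpholine at this position would help to separate these readings. On these data alone, it also remains open whether a step of this size carries over when the pyridin-3-yl on the sulfonyl sulfur is replaced, for example by 3-fluorophenyl.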